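Hydrazone series on the shared core: dropping the nitro group

The compounds below may be only part of what the source reports. "The series", "measured", "known", "first", "only" and "open" are said of these compounds alone.

Measured so far:
compound 1 `O=[N+]([O-])c1ccc(O)c(/C=N/Nc2cnc3ccccc3n2)c1` — 4320 nM
compound 2 `Clc1cccc(/C=N/Nc2cnc3ccccc3n2)c1Cl` — 7010 nM

Both compounds were tested in a functional assay on HCT-116 cells (Homo sapiens) for inhibition, read by MTT assay; on this read-out lower numbers stand for stronger inhibition and higher numbers for weaker inhibition. Compound 1 stands at the lower of the two numbers, yet its gap to compound 2 is within the usual scatter, so the two cannot be told apart on this evidence. Among the compounds with values here, compound 2 differs from compound 1 at several places at once, so no single-change step is available from the measured pair.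

The next compound, compound 3 `Oc1ccccc1/C=N/Nc1cnc2ccccc2n1`, keeps the shared core and the hydroxy group of compound 1; the change is hydrogen in place of nitro on an aromatic carbon. Within the data shown here, no measured pair shows what this change does here. Given that compound 1 sits at 4320 nM and compound 2, which carries neither a nitro nor a hydroxy group, sits at 7010 nM, the series so far spans a narrow band, and a step of modest size toward a weaker number, or none beyond the scatter, is the expectation in this assay.

Compound 3 is therefore estimated at 7000 nM, with a range of 2500 nM to 20000 nM; the step this implies is a 1.6-fold higher number from compound 1 to compound 3 (0.21 log units; within the scatter) and is expected to stay close to the scatter.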

Compound 3, half-maximal inhibitory concentration: 4940 nM
The estimate for compound 3 lay 1.4-fold (0.15 log units) above the measured number; low and high end bracket the measured number.
By their numbers in this assay, from the lowest: compounds 1, 3 and 2 (each within the scatter of the next).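

In this assay, within the data shown here, hydrogen in place of nitro on an aromatic carbon, para to a hydroxy group and meta to a large group, gives a 1.1-fold higher number from compound 1 to compound 3 (0.06 log units; within the scatter) as the first single-change step. For this pair, the nitro group and its 3 heavy atoms can leave the ring with no difference that this read-out separates from the usual scatter, so the nitro group is not required for a value in the range held by compound 1. No accompanying evidence bears on the reason for this result, which stands as an observation only.

Going by these compounds, it remains open whether a different group at this same place, such as an amine or a carboxylic acid, would give a step beyond the scatter, since nitro and hydrogen are the only two substituents compared here. The role of the hydroxy group also remains open, as compound 1 and compound 3 both keep it and the compounds shown offer no single-change step that removes or replaces it.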